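This account rests on a few compounds, and the source may have more. Where it says the series, first, only, none or still open, it means among the compounds named here.

Measured in an ADME assay on HL-60 cells (Homo sapiens) for cytotoxicity, read by MTT assay, with a stated time of 24 h; a lower number here means a stronger inhibitor, a higher number a weaker inhibitor:
Compound 1 `CN1CCC=C(c2ccc(CN(C)CCCc3ccccc3)cc2)C1`: > 50000 nM, a limit.
Compound 2 `CC(C)CN(C)Cc1ccc(C2CCCN(C)C2)cc1`: > 50000 nM, a limit.
Compound 3 `CN(Cc1ccc(Cl)cc1)Cc1ccc(C2CCCN(C)C2)cc1`: > 50000 nM, a limit.

Compound 3 therefore has no exact value, and neither of the other two compounds offers a number to rank it against. Compound 4 `CN(CCCc1ccccc1)Cc1ccc(C2CCCN(C)C2)cc1` is the next case. The change is phenethyl in place of 4-chlorophenyl on a saturated chain carbon bound to an amine nitrogen. Among the compounds with values here, the one measured step at this place, a step that the two limits leave unreadable from compound 2 to compound 3, gives no size to carry over. Within the data shown here, the only guide is the limit of > 50000 nM in this assay, at which 3 of the 3 values shown sit. No step beyond the scatter is expected, and the estimated a number no higher from compound 3 to compound 4 (the limit leaves the size open) has no direction that the data support. For compound 4 the expected value is 50000 nM, with an estimated range of 20000 nM to 100000 nM.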

Compound 4, half-maximal inhibitory concentration: > 50000 nM
Compound 4: a limit, no number (the forecaster's own chance of this, stated with the estimate: 75%); the middle value sits exactly at the limit.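

In this assay compound 4 gives only a limit, so its steps from compound 1, compound 2 and compound 3 cannot be read. The compounds shown leave open whether any of these changes alters cytotoxicity at all: the limit of > 50000 nM in this assay, at which 4 of the 4 values shown sit.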